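Swapping a hydroxy group for hydrogen in compound 1

The source may hold more compounds than are shown below. What is called first, only, known or untested is meant among the compounds shown, and "the series" means these compounds.

Compounds measured in a functional assay on DU-145 cells (Homo sapiens) for inhibition, read by trypan blue exclusion, with a stated time of 96 h; on this read-out lower numbers stand for stronger inhibition of growth and higher numbers for weaker inhibition of growth:
compound 1 `COc1ccc(C(=O)/C(=C\c2ccc(OC)c(O)c2)Sc2ccc(F)cc2)cc1`: 1000 nM
compound 2 `Cc1ccc(S/C(=C/c2c[nH]c3ccc(Br)cc23)C(=O)c2ccc(Cl)cc2)cc1`: 1000 nM
compound 3 `Cc1ccc(S/C(=C/c2c[nH]c3ccccc23)C(=O)c2ccc(Cl)cc2)cc1`: 10000 nM

Compound 1 stands level with compound 2, and these two share the lowest number of the three. Compound 4 `COc1ccc(/C=C(/Sc2ccc(F)cc2)C(=O)c2ccc(OC)cc2)cc1`, not yet measured, has hydrogen in place of hydroxy on an aromatic carbon. Among the compounds with values here, the only measured step, a 10-fold higher number from compound 2 to compound 3 (1.00 log units; beyond the scatter), also puts hydrogen on an aromatic carbon, but it replaces bromo on a different core, so it is only a loose guide. It suggests that compound 4 will show weaker inhibition in this assay, by a smaller step. The expected step is a 3.0-fold higher number from compound 1 to compound 4 (0.48 log units; beyond the scatter). Compound 4 is estimated at 3000 nM, with an expected range of 800 nM to 10000 nM.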

Compound 4, concentration for 50% growth inhibition: 25000 nM
Compound 4: middle estimate off by 8.3-fold (0.92 log units), on the low side; measured number outside the range, above it.
By their numbers in this assay, from the lowest: compounds 1 and 2 (each within the scatter of the next); then compound 3; then compound 4.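

Taking away the hydroxy group, so that 3-hydroxy-4-methoxyphenyl becomes 4-methoxyphenyl, gives a 25-fold higher number from compound 1 to compound 4 (1.40 log units; beyond the scatter) in this assay, a large loss of growth inhibition from a change of a single heavy atom. This shows that the place ortho to the methoxy group matters strongly on the core of compound 1, which the step on the other core could not show. Nothing at hand explains the size of this loss. Still open, as far as these compounds go, is whether an amine at this place could stand in for the hydroxy group. Also open, from the compounds shown here alone, is whether the same change would cost as much on the core of compound 2.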